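Trifluoromethyl in place of fluoro on the amide aryl ring

The source may hold more compounds than are shown below. What is called first, only, known or untested is meant among the compounds shown, and "the series" means these compounds.

The compounds share one core and differ only in the aryl group carried on the amide-type nitrogen. Compound 1 `O=C(Nc1ccc(Cl)cc1)c1cc(=O)[nH]c2cc(Br)ccc12` carries a 4-chlorophenyl. In a functional assay on KYSE-70 cells for antiproliferative activity against KYSE-70 cell line (Homo sapiens), read by MTT assay, with a stated time of 72 h (on this read-out lower numbers stand for stronger inhibition and higher numbers for weaker inhibition), compound 1 gives only the limit > 20000 nM, not a number. Compound 2 `O=C(Nc1ccc(F)cc1)c1cc(=O)[nH]c2cc(Br)ccc12` carries a 4-fluorophenyl; in this assay compound 2 likewise gives the limit > 20000 nM. Among the measured compounds shown here, compound 3 `O=C(Nc1cccc(F)c1)c1cc(=O)[nH]c2cc(Br)ccc12`, with a 3-fluorophenyl, is the one compound with a number: in this assay compound 3 gives 8900 nM. For the measured compounds named here, since two compounds sit at the limit of > 20000 nM in this assay, at which 2 of the 3 values shown sit, compound 3 stands as the only readable value. The steps of an at least 2.2-fold lower number from compound 1 to compound 3 (0.35 log units; beyond the scatter) and an at least 2.2-fold lower number from compound 2 to compound 3 (0.35 log units; beyond the scatter) are both at least modest. The remaining step, a step that the two limits leave unreadable from compound 1 to compound 2, cannot be read from the two limits.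

Compound 4 `O=C(Nc1cccc(C(F)(F)F)c1)c1cc(=O)[nH]c2cc(Br)ccc12` differs from compound 3 by trifluoromethyl in place of fluoro on an aromatic carbon. Going by the values given here, no measured step exchanges fluoro for trifluoromethyl; the two measured steps toward compound 3 both swapped the whole aryl group rather than enlarging a substituent, so they bear on compound 4 only in showing that the 3-substituted pattern is the one that yields a number. The change is therefore expected to stay within or near the scatter, in either direction. For compound 4 the estimated value in this assay is 7000 nM, between 2500 nM and 20000 nM, which would mean an expected step of a 1.3-fold lower number from compound 3 to compound 4 (0.10 log units; within the scatter).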

Compound 4, half-maximal inhibitory concentration: > 20000 nM
Compound 4: no number, only a limit; the forecaster's own chance of this, stated with the estimate: 25%; at least 2.8-fold (0.45 log units) between middle value and limit.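

Keeping the substituent at the same place on the aryl ring, on an aromatic carbon meta to a large group, and exchanging only the group itself, trifluoromethyl in place of fluoro, gives an at least 2.2-fold higher number from compound 3 to compound 4 (0.35 log units; beyond the scatter). The earlier steps shown here each swapped the whole aryl group, leaving open whether this place alone was enough for a readable value; this step shows that it is not, and that the group sitting there also counts. In this assay compound 4 gives only a limit, not a number, and compound 3 remains the one compound with a readable value: the limit of > 20000 nM in this assay, at which 3 of the 4 values shown sit.

The limits leave no order to read among compound 1, compound 2 and compound 4, and with a single number in the set, no trend across substituents can be drawn. Still open, as far as these compounds go, is whether a chlorine, a methyl, a methoxy, an amine or a carboxylic acid at this same place would give a number, and if so whether any of them would differ from compound 3 by more than the usual scatter.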